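Lengthening a Saturated Chain on Two Related Cores

The source may hold more compounds than are shown below. What is called first, only, known or untested is meant among the compounds shown, and "the series" means these compounds.

Compound 1 `CN(C)C(=O)c1cc2cnc(Nc3ccc(C(=O)NCCCCCCN=C=S)cc3F)nc2n1C1CCCC1` and compound 2 `CN(C)C(=O)c1cc2cnc(Nc3ccc(C(=O)NCCCCCCCN=C=S)cc3F)nc2n1C1CCCC1` share one core and differ in a single place: a group of 4 heavy atoms (2 carbon, 1 nitrogen, 1 sulfur; no ring) in place of a group of 3 heavy atoms (1 carbon, 1 nitrogen, 1 sulfur; no ring), on a saturated chain carbon, six bonds along the chain from an amide-type nitrogen. In a functional assay on NCI-H1299 cells (Homo sapiens) for inhibition, read by CCK-8 assay, with a stated time of 72 h, tested at 1 uM (a lower number here means a weaker effect, a higher number a stronger effect of the compound at the concentration tested), compound 1 gives 29.1%, and compound 2 gives -9.23%; the step of a number 38.3 percentage points lower from compound 1 to compound 2 (beyond the scatter). Compound 3 `CN(C)C(=O)c1cc2cnc(Nc3ccc(NC(=O)CCCCCN=C=S)cc3)nc2n1C1CCCC1` carries a second core; the difference between the two cores is not broken down here. In this assay compound 3 gives 34.3%, which lies within the scatter of compound 1 and well above compound 2. Compound 4 `CN(C)C(=O)c1cc2cnc(Nc3ccc(NC(=O)CCCCCCN=C=S)cc3)nc2n1C1CCCC1` has not yet been measured. It differs from compound 3 by a group of 4 heavy atoms (2 carbon, 1 nitrogen, 1 sulfur; no ring) in place of a group of 3 heavy atoms (1 carbon, 1 nitrogen, 1 sulfur; no ring), on a saturated chain carbon, five bonds along the chain from a carbonyl carbon. This is the same kind of change as that from compound 1 to compound 2, though the place is described differently: six bonds along the chain from an amide-type nitrogen there, five bonds along the chain from a carbonyl carbon here. For the measured compounds named here, the step this estimate means, a number 29.3 percentage points lower from compound 3 to compound 4 (beyond the scatter), is expected to be a fall, because the one measured example a number 38.3 percentage points lower from compound 1 to compound 2 (beyond the scatter) of this kind of change was large, with the reservation that a single example on a different core is a thin basis. Compound 4 is therefore estimated at 5%, between -20% and 30%.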

Compound 4, a percentage reported as inhibition, at one concentration (the size of the read-out at that concentration, not a potency): 50.9%
For compound 4 the middle estimate is 45.9 percentage points below the measured one; measured number above the stated range.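

In this assay, lengthening the chain on the core of compound 3 gives a number 16.6 percentage points higher from compound 3 to compound 4 (beyond the scatter), so the fall seen on the core of compound 1 does not carry over, and the two steps run in opposite directions: the same change on two cores in this assay, a number 38.3 percentage points lower (beyond the scatter) from compound 1 to compound 2 and a number 16.6 percentage points higher (beyond the scatter) from compound 3 to compound 4, 54.9 percentage points apart, beyond the scatter of two such steps This shows that, in these two pairs, the outcome of adding this chain carbon depends on the core that carries it, and that a step measured on one core cannot simply be transferred to the other. It does not show which difference between the two cores is responsible, and with a single step on each core it gives no general rule for chain length on either one.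

The compounds shown leave open whether a still longer chain on the core of compound 4 would raise the read-out further or reverse it, as the step on the other core did. They also leave open how an amine at the chain end would compare, and whether these stronger and weaker effects at a single concentration would hold at other concentrations.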